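Tetrabromobenzotriazole hydroxypropyl aryl series: antiproliferative read-out

The compounds below may be only part of what the source reports. "The series", "measured", "known", "first", "only" and "open" are said of these compounds alone.

Measured so far:
compound 1 `OC(CCn1nc2c(Br)c(Br)c(Br)c(Br)c2n1)c1cccc(Br)c1` — 0%
compound 2 `OC(CCn1nc2c(Br)c(Br)c(Br)c(Br)c2n1)c1ccc(F)cc1` — 0%

In a functional assay on MCF7 cells (Homo sapiens) for antiproliferative activity, read by MTT assay, with a stated time of 48 h, tested at 100 uM (on this read-out higher numbers stand for a weaker effect at the one concentration tested and lower numbers for a stronger effect), compound 1 gives 0% and compound 2 gives 0%. Compound 2 therefore stands level with compound 1 at the digits printed; the step of no change at the digits printed from compound 1 to compound 2 (within the scatter) lies within the scatter, although it exchanges the whole aryl group on the saturated chain carbon bound to the oxygen.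

Compound 3 `OC(CCn1nc2c(Br)c(Br)c(Br)c(Br)c2n1)c1ccccc1` is the next member to be measured in this assay. It differs from compound 2 by hydrogen in place of fluoro on an aromatic carbon; cut one bond further out, the difference reads 4-fluorophenyl to phenyl. Going by the values given here, the only step measured so far, from compound 1 to compound 2, bears on it, since it also alters this aryl group, and it produced no change beyond the scatter. A step of the same kind, no change at the digits printed from compound 2 to compound 3 (within the scatter), is expected here, with no movement beyond the scatter in either direction. Compound 3 is therefore estimated at 0% in this assay, within the range 0% to 12%.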

Compound 3, a percentage reported as activity, at one concentration (the size of the read-out at that concentration, not a potency): 0%
Compound 3: the middle estimate sits on the measured number at the digits printed; the range from low to high includes it.
By their numbers in this assay, from the lowest: compounds 1, 2 and 3 (each within the scatter of the next).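

Compound 3 supplies the unsubstituted phenyl member that the earlier pair lacked. Hydrogen in place of a ring halogen leaves this assay unmoved, with no change at the digits printed from compound 2 to compound 3 (within the scatter) for the loss of fluoro and no change at the digits printed from compound 1 to compound 3 (within the scatter) for the loss of bromo. On this read-out, at the one concentration tested, neither halogen separates from hydrogen on the aromatic ring, and no supporting measurement accounts for this flat result.

The compounds shown leave open whether a different kind of ring group, such as an amine or a carboxylic acid, would give a different reading. Also open, on these data alone, is whether a longer chain between the shared core and the aryl group would shift the reading, or whether the core alone sets it.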